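The compounds below may be only part of what the source reports. "The series", "measured", "known", "first", "only" and "open" are said of these compounds alone.

Measured in a functional assay on HepG2 cells (Homo sapiens) for antiproliferative activity, read by MTT assay, with a stated time of 72 h; a lower number here means a stronger inhibitor, a higher number a weaker inhibitor:
- Compound 1 `O=C(N/N=C/c1ccccc1)Nc1ccc(Oc2ccnc3[nH]ccc23)cc1`: 750 nM
- Compound 2 `O=C(N/N=C/c1ccc(F)cc1)Nc1ccc(Oc2ccnc3[nH]ccc23)cc1`: 3430 nM
- Compound 3 `O=C(N/N=C/c1cccc(Cl)c1Cl)Nc1ccc(Oc2ccnc3[nH]ccc23)cc1`: "not active" (no number reported)

In this assay, within the data shown here, compound 3 gives "not active" (no number reported), so it has no place on the number scale and no step can be counted from it. Compound 4 `CN(C)CCn1cccc1/C=N/NC(=O)Nc1ccc(Oc2ccnc3[nH]ccc23)cc1` carries 1-(2-(dimethylamino)ethyl)-1H-pyrrol-2-yl in place of 2,3-dichlorophenyl on a carbon with a double bond to nitrogen. Among the measured compounds shown here, the only measured step, a 4.6-fold higher number from compound 1 to compound 2 (0.66 log units; beyond the scatter), is a fluoro in place of hydrogen on an aromatic carbon, so it bears on this swap only loosely. A move towards a measurable, stronger result is expected, of a size the data cannot fix. The range of compound 1 and compound 2 serves as the guide. For compound 4 the expected value in this assay is 1200 nM, within an estimated range of 200 nM to 7000 nM.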

Compound 4, half-maximal inhibitory concentration: "not active" (no number reported)
The entry for compound 4 holds no number; no gap can be computed for the estimate.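

Compound 3 gives "not active" (no number reported) and compound 4 gives "not active" (no number reported) in this assay, so no step can be read between them. No supporting evidence bears on this result. As far as these compounds go, how 1-(2-(dimethylamino)ethyl)-1H-pyrrol-2-yl compares with 2,3-dichlorophenyl on the number scale stays open.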